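Bromo in place of the acid-bearing chain end

The compounds below may be only part of what the source reports. "The series", "measured", "known", "first", "only" and "open" are said of these compounds alone.

Compound 2 `O=C(O)CCCCCCCCCOc1ccc2c(=O)c(-c3ccc(O)cc3)coc2c1` stands lowest of the two numbers measured in an assay on isolated protein (Cricetulus griseus) for inhibition of aldehyde dehydrogenase, mitochondrial (Homo sapiens); on this read-out higher numbers stand for weaker inhibition and lower numbers for stronger inhibition; compound 2 gives 4 nM. Within the data shown here, its nearest neighbour is compound 1 `O=C(O)CCCCCCOc1ccc2c(=O)c(-c3ccc(O)cc3)coc2c1`, which in this assay gives 9 nM; the single measured step, a 2.3-fold lower number from compound 1 to compound 2 (0.35 log units; beyond the scatter), is modest but beyond the scatter. Compound 3 `O=c1c(-c2ccc(O)cc2)coc2cc(OCCCCCCBr)ccc12` is not yet measured. It differs from compound 2 by bromo in place of 3-carboxypropyl on a saturated chain carbon, six bonds along the chain from an oxygen on an aromatic ring. Among the measured compounds shown here, the measured step of a 2.3-fold lower number from compound 1 to compound 2 (0.35 log units; beyond the scatter) alters only the length of the chain that carries the carboxy group and leaves that group in place, so no measured step bears on removing it altogether. With both measured compounds close together in this assay and nothing that speaks to the bromo, the direction of the step is open; a somewhat higher number is taken as the more likely outcome, with a wide range on either side. The step expected here is a 3.8-fold higher number from compound 2 to compound 3 (0.57 log units; beyond the scatter). Compound 3 is therefore estimated at 15 nM, between 3 nM and 80 nM.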

Compound 3, half-maximal inhibitory concentration: 300 nM
Compound 3: the middle estimate sits 20-fold (1.30 log units) below what was measured; the whole stated range lies below it.
By their numbers in this assay, from the lowest: compound 2; then compound 1; then compound 3.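

In this assay, the group at the chain end proves to matter far more than the chain length: with the chain held the same, bromo in place of carboxy on a saturated chain carbon, six bonds along the chain from an oxygen on an aromatic ring, gives the large step (a 33-fold higher number from compound 1 to compound 3 (1.52 log units; beyond the scatter)). Bromo in place of 3-carboxypropyl gives a large step of similar order (a 75-fold higher number from compound 2 to compound 3 (1.88 log units; beyond the scatter)), whereas the chain change between the two acid-bearing compounds was only modest (a 2.3-fold lower number from compound 1 to compound 2 (0.35 log units; beyond the scatter)). Weaker inhibition thus goes with the loss of the carboxy group in both comparisons, but nothing available explains the size of these steps.

The compounds shown do not separate the loss of the carboxy group from the arrival of bromo, and a plain methyl or hydroxy chain end would bear on that, while a methyl ester, primary amide or tetrazole would test how specific the requirement for a carboxylic acid is. On these data alone, whether bromo on the longer chain of compound 2 behaves as it does on the shorter chain of compound 3 also remains open.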